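The source may report more compounds than this note shows. Statements on the series, on what has been measured and on what is new or still open speak of the compounds shown alone.

Working notes on the series in an ADME assay on S2 cells (Drosophila melanogaster) for cytotoxicity, read by MTT assay; on this read-out higher numbers stand for an effect only at larger amounts of compound and lower numbers for an effect already at smaller amounts.

Compound 1 `COC(=O)/C=C/[C@H]1C[C@@H](O)[C@@H](O)C1` is the reference point. In this assay compound 1 gives > 350000 nM, which is a limit of the assay and not a number, so compound 1 stands only at a limit, as do the other two values. Compound 2 `CCCCCCOC(=O)/C=C/[C@H]1C[C@@H](O)[C@@H](O)C1` carries pentyl in place of hydrogen on a saturated chain carbon bound to an oxygen next to a carbonyl group; in this assay compound 2 gives > 350000 nM, again a limit. Compound 3 `O=C(/C=C/[C@H]1C[C@@H](O)[C@@H](O)C1)NC1CC1` carries cyclopropylamino in place of methoxy on a carbonyl carbon; in this assay compound 3 gives > 250000 nM, also a limit. Accordingly a step that the two limits leave unreadable from compound 1 to compound 2 and a step that the two limits leave unreadable from compound 1 to compound 3. Two of the three values sit at the limit of > 350000 nM in this assay, at which 2 of the 3 values shown sit, and one at the limit of > 250000 nM in this assay, at which 1 of the 3 values shown sits.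

Compound 4 `O=C(/C=C/[C@H]1C[C@@H](O)[C@@H](O)C1)NO` differs from compound 1 by hydroxyamino in place of methoxy on a carbonyl carbon. Both measured steps, one at the ester chain and one at the carbonyl substituent, stay unreadable and give no sign of any effect below the limits. For compound 4 the expected step is a number no higher from compound 1 to compound 4 (the limit leaves the size open), that is, none beyond the scatter. Compound 4 is therefore estimated at 350000 nM, with a range from 150000 nM to 1000000 nM, and is most likely to be reported again only as a limit.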

Compound 4, half-maximal effective concentration: > 250000 nM
Compound 4 gave a limit, no number; the forecaster's own chance of this, stated with the estimate: 85%; the middle value is on the limit's open side.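

In this assay compound 4 gives > 250000 nM, which is a limit of the assay and not a number. The steps to compound 4 from compound 1 and from compound 3 therefore cannot be read. The compounds shown leave open where any half-maximal effective concentration lies and whether any of these changes alters it.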